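This account rests on a few compounds, and the source may have more. Where it says the series, first, only, none or still open, it means among the compounds named here.

In a functional assay on HCT-116 cells (Homo sapiens) for cytotoxicity (a higher number here means a weaker inhibitor, a lower number a stronger inhibitor), two compounds sharing one core have been measured. Compound 1 `O=C1NC(=O)c2c1c1c3ccc(C(F)(F)F)cc3[nH]c1c1c2c2cccc3c2n1CCC3` gives 1480 nM, and compound 2 `O=C1NC(=O)c2c1c1c3ccc(-c4ccncc4)cc3[nH]c1c1c2c2cccc3c2n1CCC3` gives 3290 nM, the higher of the two numbers and so the weaker result. Still unmeasured is compound 3 `O=C1NC(=O)c2c1c1c3ccc(CN4CCCC4)cc3[nH]c1c1c2c2cccc3c2n1CCC3`, which keeps the core and changes one group: (pyrrolidin-1-yl)methyl in place of pyridin-4-yl on an aromatic carbon. Going by the values given here, the only measured step at this place is modest, a 2.2-fold higher number from compound 1 to compound 2 (0.35 log units; beyond the scatter). Among the compounds with values here, one step sets no rule, and no measured compound carries a non-aromatic ring here. A step of similar size is expected, leaning towards a lower number and the level of compound 1 at 1480 nM, though the direction is uncertain. The expected step is a 1.8-fold lower number from compound 2 to compound 3 (0.26 log units; within the scatter). For compound 3 the estimated value is 1800 nM, with a range of 600 nM to 5000 nM.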

Compound 3, half-maximal inhibitory concentration: 170 nM
The estimate for compound 3 lay 11-fold (1.02 log units) above the measured number, and the stated range ends above it.
By their numbers in this assay, from the lowest: compound 3; then compound 1; then compound 2.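

In this assay, going by these compounds alone, a change at this aromatic carbon can shift the number far more than the single earlier step suggested (a 19-fold lower number from compound 2 to compound 3 (1.29 log units; beyond the scatter)). The (pyrrolidin-1-yl)methyl group also stands clearly apart from trifluoromethyl (an 8.7-fold lower number from compound 1 to compound 3 (0.94 log units; beyond the scatter)), and it does so while matching pyridin-4-yl in heavy atoms, nitrogen count and hydrogen-bond donors and acceptors, so those counts do not separate the two groups, although the five-membered non-aromatic ring replaces a six-membered aromatic one. Nothing available explains why the number falls.

The compounds shown cannot tell whether the gain depends on the pyrrolidine ring itself or would also appear with an open-chain dimethylaminomethyl group or a larger piperidin-1-ylmethyl group. They also leave open what happens when the pyrrolidine ring sits directly on the aromatic carbon, without the connecting methyl carbon.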